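The source may report more compounds than this note shows. Statements on the series, on what has been measured and on what is new or still open speak of the compounds shown alone.

Of the compounds shown here, three that share a core have been measured so far in a physicochemical assay for lipophilicity, using the shake flask method, measured as octanol-water partition, with a stated time of 24 h (a lower number here means a more polar compound, a higher number a more lipophilic compound), and all lie close together. Compound 1 (`Cc1cc2ncn(CC(O)COc3cc4oc(=O)cc(C)c4cc3OCC(O)Cn3cnc4cc(C)c(C)cc43)c2cc1C`) gives 0.61 there, compound 2 (`Cc1cc(=O)oc2cc(OCC(O)CSc3nc4ccccc4[nH]3)ccc12`) gives 0.49 there, and compound 3 (`Cc1cc(=O)oc2cc(OCC(O)Cn3cncn3)ccc12`) gives 0.45 there. Compound 3 therefore stands within the scatter of both other compounds, and the three numbers cannot be ranked.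

Compound 4 (`Cc1cc(=O)oc2cc(OCC(O)Cn3cncn3)c(OCC(O)Cn3cncn3)cc12`) has not yet been measured. It differs from compound 3 by 3-(1H-1,2,4-triazol-1-yl)-2-hydroxypropoxy in place of hydrogen on an aromatic carbon and so gains a 3-(1H-1,2,4-triazol-1-yl)-2-hydroxypropoxy group on an aromatic carbon, ortho to the one already there. For the measured compounds named here, no measured pair shows this change directly. The closest guide is compound 1, which also carries two side chains on its core and whose 0.61 lies within the scatter of the other two. Only a small downward step is therefore expected in this assay and it may not exceed the scatter. The estimate is a number 0.10 log units lower from compound 3 to compound 4 (within the scatter) for this change. Compound 4 is expected at 0.35 (estimated range 0.05 to 0.6).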

Compound 4, partition coefficient: 0.65
The estimate for compound 4 lay 0.30 log units below the measured number; the whole stated range lies below it.
By their numbers in this assay, from the lowest: compounds 3, 2, 1 and 4 (each within the scatter of the next).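

In this assay, for the compounds shown here, the change reads as a number 0.20 log units higher from compound 3 to compound 4 (within the scatter), and this single pair is the first direct view of the position. It shows that this aromatic carbon, ortho to a 3-(1H-1,2,4-triazol-1-yl)-2-hydroxypropoxy group, can carry a second such group, with its 10 heavy atoms and five-membered aromatic ring, while the two numbers remain within the scatter of each other. The data offer no measured explanation for this result.

The step rests on one pair and one core, so it cannot be said whether the same change would read alike elsewhere. On these data alone, it also remains open what this position would give with a group ending in an amine or a carboxylic acid in place of the triazole, or with a longer chain between the ring and the oxygen.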